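The source may report more compounds than this note shows. Statements on the series, on what has been measured and on what is new or still open speak of the compounds shown alone.

Three measured compounds share one core and differ only in the group on the amide-type nitrogen: compound 1 `Cn1ccc2ccc(-c3cc(Nc4cnccc4C(=O)NC4CCNC(=O)C4)cc4nccnc34)cc21`, compound 2 `CN1CCC(NC(=O)c2ccncc2Nc2cc(-c3ccc4ccn(C)c4c3)c3nccnc3c2)CC1=O` and compound 3 `CN1CC(NC(=O)c2ccncc2Nc2cc(-c3ccc4ccn(C)c4c3)c3nccnc3c2)CCC1=O`. In an assay for inhibition of 6-phosphofructo-2-kinase/fructose-2,6-bisphosphatase 3 (Homo sapiens), read by ADP-Glo, with a stated time of 2 h (on this read-out higher numbers stand for weaker inhibition and lower numbers for stronger inhibition), compound 1 gives 69 nM, compound 2 gives 41 nM and compound 3 gives 116 nM. Compound 3 thus stands at the highest number of the three, though one of the gaps is small (a 1.7-fold higher number from compound 1 to compound 3 (0.23 log units; within the scatter)), while the other is larger (a 2.8-fold higher number from compound 2 to compound 3 (0.45 log units; beyond the scatter)); the step of a 1.7-fold lower number from compound 1 to compound 2 (0.23 log units; within the scatter) stays within the scatter.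

Compound 4 `CC(=O)N1CCOC(CNC(=O)c2ccncc2Nc2cc(-c3ccc4ccn(C)c4c3)c3nccnc3c2)C1` takes the same position further: (4-acetylmorpholin-2-yl)methyl in place of 1-methyl-6-oxopiperidin-3-yl on an amide-type nitrogen. For the measured compounds named here, the steps that bear on this are those at the amide-type nitrogen, and both were modest in size. The new change is larger, replacing the ring and its attachment, yet nothing measured points to a direction beyond the scatter. Compound 4 is therefore expected to lie near compound 3, with a 1.1-fold lower number from compound 3 to compound 4 (0.02 log units; within the scatter) expected, giving an estimate of 110 nM in this assay, within a range from 40 nM to 300 nM.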

Compound 4, half-maximal inhibitory concentration: 93 nM
Estimate against measurement, compound 4: 1.2-fold (0.07 log units) above; measured number inside the range.
By their numbers in this assay, from the lowest: compounds 2, 1, 4 and 3 (each within the scatter of the next, the first and the last beyond it).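

In this assay, for the compounds shown here, the position tolerates a larger change than the earlier compounds showed: replacing 1-methyl-6-oxopiperidin-3-yl with (4-acetylmorpholin-2-yl)methyl changes the ring and its attachment, yet the step stays within the scatter (a 1.2-fold lower number from compound 3 to compound 4 (0.10 log units; within the scatter)). Compound 4 also stays within the scatter of the compound carrying 2-oxopiperidin-4-yl (a 1.3-fold higher number from compound 1 to compound 4 (0.13 log units; within the scatter)). Only the comparison with the 1-methyl-2-oxopiperidin-4-yl group exceeds the scatter, and modestly (a 2.3-fold higher number from compound 2 to compound 4 (0.36 log units; beyond the scatter)), so this position has now held three different ring groups and a change of attachment without a large loss or gain.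

Nothing given here explains these steps. From the compounds shown here alone, it remains open whether a group without a ring on the amide-type nitrogen, such as a 2-aminoethyl chain or a longer chain ending in a carboxylic acid, would stay in this range.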